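The source may hold more compounds than are shown below. What is called first, only, known or untested is meant among the compounds shown, and "the series" means these compounds.

Measured so far in a physicochemical assay for solubility, read by HPLC, in phosphate buffer, measured as kinetic solubility, with a stated time of 24 h, at pH 7.4, tested at 200 uM; a lower number here means a less soluble compound, a higher number a more soluble compound:
- compound 1 `CCc1cccc(CC)c1N1CCn2cc(-c3nc(Nc4ccc(N5CCC(N6CCN(C)CC6)CC5)cc4OC)nc4[nH]ccc34)cc2C1=O`: 6000 nM
- compound 2 `CCc1cccc(CC)c1N1CCn2cc(-c3nc(Nc4ccc(N5CCN(CC(=O)N(C)C)CC5)cc4OC)nc4[nH]ccc34)cc2C1=O`: 1400 nM

Of these two numbers, compound 1 holds the higher one. Compound 2 holds the lower one, and the gap lies beyond the usual scatter of repeated measurements. The next compound to be tested is compound 3 `CCc1cccc(CC)c1N1CCn2cc(-c3nc(Nc4ccc(N5CCC(C(=O)N6CCN(C)CC6)CC5)cc4OC)nc4[nH]ccc34)cc2C1=O`, and it departs from compound 1 in a single place: (4-methylpiperazin-1-yl)carbonyl in place of 4-methylpiperazin-1-yl on a saturated ring carbon. Put simply, (4-methylpiperazin-1-yl)carbonyl stands in place of 4-methylpiperazin-1-yl on a saturated ring carbon, so a carbonyl now sits where the two rings used to join directly.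

Within the data shown here, the two measured compounds differ in more than one place, so the data hold no direct step to lean on. The only hint is weak: compound 2, whose side chain also contains a carbonyl, gives 1400 nM. A modest fall in this assay is therefore expected, near the edge of the scatter. The expected change is a 2.0-fold lower number from compound 1 to compound 3 (0.30 log units; within the scatter). For compound 3 the estimated value is 3000 nM, with an expected range of 900 nM to 10000 nM.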

Compound 3, solubility: 800 nM
Compound 3: the middle estimate sits 3.8-fold (0.57 log units) above what was measured; the whole stated range lies above it.
By their numbers in this assay, from the lowest: compounds 3 and 2 (each within the scatter of the next); then compound 1.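

Within this assay the change from 4-methylpiperazin-1-yl to (4-methylpiperazin-1-yl)carbonyl on a saturated ring carbon gives a 7.5-fold lower number from compound 1 to compound 3 (0.88 log units; beyond the scatter) and so supplies the first direct reading at this position. The earlier pair differed in more than one place, so it could not isolate any single change, whereas here everything else in the molecule stays fixed. The six-membered ring with its two hetero atoms remains, both groups have the same counts of hydrogen-bond donors and acceptors, and neither carries a net charge, so even a swap this small in those counts is tied to a clear drop in the number, yet nothing measured here explains that drop.

This single step cannot separate the effect of the carbonyl from that of moving the 4-methylpiperazine ring further from the saturated ring carbon, and a methylene link in place of the carbonyl would help to tell these apart. It also leaves open how a smaller group at the same carbon, such as a dimethylamino group, would compare with 4-methylpiperazin-1-yl.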